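Swapping the aryl tail: cytotoxicity expected to stay low

This account rests on a few compounds, and the source may have more. Where it says the series, first, only, none or still open, it means among the compounds named here.

Compound 2 `COc1cccc(-c2ccc(C(=O)N(Cc3cccc(OCCCCCC(=O)O)c3)C(C)C)cc2)c1` carries a 3-methoxyphenyl on the shared core. In an ADME assay on HEK293 cells (Homo sapiens) for cytotoxicity, read by CellTiter-Glo and resazurin assay, with a stated time of 72 h (a higher number here means that more compound is needed for the effect, a lower number that less compound is needed), compound 2 reaches only a limit of the assay, > 20900 nM. Its nearest neighbour, compound 1 `CC(C)N(Cc1cccc(OCCCCCC(=O)O)c1)C(=O)c1ccc(-c2ccsc2)cc1`, carries a thiophen-3-yl in the same place. In this assay compound 1 likewise gives a limit, > 26000 nM. The step that the two limits leave unreadable from compound 1 to compound 2 is therefore unreadable, because both numbers are limits the limit of > 20900 nM in this assay, at which 1 of the 2 values shown sits, and (the limit of > 26000 nM in this assay, at which 1 of the 2 values shown sits). Compound 3 `CC(C)N(Cc1cccc(OCCCCCC(=O)O)c1)C(=O)c1ccc(-c2ccc3cc[nH]c3c2)cc1` is the next compound: 1H-indol-6-yl in place of 3-methoxyphenyl on an aromatic carbon. Going by the values given here, no measured step tells how this change acts, since the only comparison available gives no size. The expectation for compound 3 is therefore that it too stays beyond the reach of this assay, with an estimated 25000 nM (range 8000 nM to 80000 nM). That estimate means an expected step that the limit leaves unreadable from compound 2 to compound 3 of no readable size.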

Compound 3, half-maximal effective concentration: > 26000 nM
Compound 3 gave a limit, no number; the forecaster's own chance of this, stated with the estimate: 75%; middle value at least 1.0-fold (0.01 log units) from the limit.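

Compound 3, like compound 1 and compound 2, gives only a limit in this assay, so the steps from compound 1 and compound 2 to compound 3 cannot be read. The compounds shown leave open what concentration of any of the three would produce the effect.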